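This account rests on a few compounds, and the source may have more. Where it says the series, first, only, none or still open, it means among the compounds named here.

In a functional assay on K562 cells (Homo sapiens) for antiproliferative activity, with a stated time of 72 h (on this read-out lower numbers stand for stronger inhibition and higher numbers for weaker inhibition), compound 2 (`COc1ccccc1CNc1ncnc2c1ncn2[C@@H]1O[C@H](CO)[C@@H](O)[C@H]1O`) gives 89000 nM. Compound 1 (`Cc1cccc(CNc2ncnc3c2ncn3[C@@H]2O[C@H](CO)[C@@H](O)[C@H]2O)c1`) gives > 166000 nM, which is a limit. Compound 3 (`COc1cccc(CNc2ncnc3c2ncn3[C@@H]2O[C@H](CO)[C@@H](O)[C@H]2O)c1OC`) gives > 166000 nM, also a limit; this is the limit of > 166000 nM in this assay, at which 2 of the 3 values shown sit. Compound 4 (`OC[C@H]1O[C@@H](n2cnc3c(NCc4ccc(F)c(F)c4F)ncnc32)[C@H](O)[C@@H]1O`) departs from compound 3 at one place: 2,3,4-trifluorophenyl in place of 2,3-dimethoxyphenyl on a saturated chain carbon bound to a nitrogen on an aromatic ring. The nearest evidence comes from other changes to this aryl group, namely an at least 1.8-fold lower number from compound 1 to compound 2 (0.27 log units; that floor lies within the scatter) and an at least 1.8-fold higher number from compound 2 to compound 3 (0.27 log units; that floor lies within the scatter), while a step that the two limits leave unreadable from compound 1 to compound 3. These floors do not fix a size, so only a modest fall in this assay is expected. Within the data shown here, compound 2, at 89000 nM, is the sole true number and anchors that expectation. The expected change is an at least 2.7-fold lower number from compound 3 to compound 4 (0.44 log units; beyond the scatter). The estimate for compound 4 is 60000 nM, with an expected range from 10000 nM to 166000 nM.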

Compound 4, half-maximal inhibitory concentration: > 166000 nM
Compound 4 gave a limit, no number; the forecaster's own chance of this, stated with the estimate: 35%; middle value at least 2.7-fold (0.44 log units) from the limit.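

In this assay, among these compounds, a fluorinated aryl group now joins the methyl and dimethoxy aryl groups at the assay limit, leaving compound 2 as the only compound with a true number: the limit of > 166000 nM in this assay, at which 3 of the 4 values shown sit. Against that number, 2,3,4-trifluorophenyl in place of 2-methoxyphenyl gives an at least 1.8-fold higher number from compound 2 to compound 4 (0.27 log units; that floor lies within the scatter). The steps to compound 4 from compound 1 and from compound 3 cannot be read.

From the compounds shown here alone, it remains open whether an amine or a carboxylic acid on this aryl ring, or a longer chain in place of the saturated chain carbon, would give a true number.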